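The source may hold more compounds than are shown below. What is called first, only, known or untested is meant among the compounds shown, and "the series" means these compounds.

Compound 1 `COc1ccc(N(C)c2nc(C)nc3c2nc(C)n3C)cc1`: 19000 nM
Compound 2 `COc1ccc(Nc2nc(C)nc3c2nc(C)n3C)cc1`: >= 250000 nM
Compound 3 `COc1cccc(N(C)c2nc(C)nc3c2nc(C)n3C)c1`: > 250000 nM

Among the measured compounds shown here, in a functional assay on L1210 cells (Mus musculus) for inhibition, read by cell counting, with a stated time of 48 h (a lower number here means a stronger inhibitor, a higher number a weaker inhibitor), compound 1 gives 19000 nM, the only true number among the three. Compound 2 reports only a limit, >= 250000 nM. Compound 3 is an isomer of compound 1. Compound 3 likewise reports only a limit, > 250000 nM.

Compound 4 `Cc1ccc(N(C)c2nc(C)nc3c2nc(C)n3C)cc1` departs from compound 1 at a single place, with methyl in place of methoxy on an aromatic carbon, para to a large group: methyl in place of methoxy on an aromatic carbon. For the measured compounds named here, no measured step touches this group directly. Going by the values given here, the one measured step, an at least 13-fold higher number from compound 1 to compound 2 (1.11 log units; beyond the scatter), is large and beyond the scatter, but it lies at a nitrogen rather than at this carbon. It therefore bears only indirectly, showing that one small change to compound 1 can reach the limit of this assay. A moderate loss is thus expected, toward a higher number, though a result within the scatter remains possible. The expected change is a 2.6-fold higher number from compound 1 to compound 4 (0.42 log units; beyond the scatter). For compound 4 the estimated value is 50000 nM, with an expected range from 15000 nM to 250000 nM.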

Compound 4, half-maximal inhibitory concentration: >= 250000 nM
Compound 4 ended at the assay's limit; the forecaster's own chance of this, stated with the estimate: 25%; middle value at least 5.0-fold (0.69 log units) away from the limit.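

In this assay, compound 4 reports only a limit, >= 250000 nM. Among the compounds shown here, the step, an at least 13-fold higher number from compound 1 to compound 4 (1.11 log units; beyond the scatter), is the first measured step at this aromatic carbon, para to a large group, and it shows that the measurable number of compound 1 is lost with methyl in place of methoxy there, just as it was lost with hydrogen in place of methyl on the nitrogen. As far as these compounds go, the true size of the step stays unknown, since compound 4 sits at the edge of what this assay reports: the limit of >= 250000 nM in this assay, at which 2 of the 4 values shown sit.

From the compounds shown here alone, whether another group at this carbon, such as ethoxy, a hydroxyl or an amine, would keep a measurable number remains open. Compound 1 is still the only compound with a true number, so the compounds shown give no order among the others.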